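Working notes on compounds 1 to 4

The source may report more compounds than this note shows. Statements on the series, on what has been measured and on what is new or still open speak of the compounds shown alone.

Measured so far in an assay on HEK293 cells for displacement of a labelled ligand from Neuronal acetylcholine receptor; alpha4/beta2 (Homo sapiens), read by scintillation counting, with a stated time of 120 min; on this read-out higher numbers stand for weaker inhibition and lower numbers for stronger inhibition:
compound 1 `Fc1cccc(-c2cn(C3CN4CCC3CC4)nn2)c1` gives 748 nM
compound 2 `c1ccc(COc2cccc(-c3cn(C4CN5CCC4CC5)nn3)c2)cc1` gives 668 nM
compound 3 `c1ccc(COc2cccc(-c3cn([C@H]4CN5CCC4CC5)nn3)c2)cc1` gives 5060 nM

Compound 1 differs from compound 2 by fluoro in place of benzyloxy on an aromatic carbon; the step is a 1.1-fold higher number from compound 2 to compound 1 (0.05 log units; within the scatter). Compound 3 differs from compound 2 by the two compounds have the same atoms and bonds; at least one stereo element is drawn with a configuration in one of them and without one in the other: 1 of 3 stereo elements differ; a stereocentre at a saturated ring carbon is drawn without a configuration in compound 2 and R in compound 3, and the step is a 7.6-fold higher number from compound 2 to compound 3 (0.88 log units; beyond the scatter), which may be due to the fact that one of compounds 2 and 3 is drawn with a defined configuration and the other without, at the place where they differ. Compound 3 thus stands highest of the three numbers.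

Compound 4 `Fc1cccc(-c2cn([C@H]3CN4CCC3CC4)nn2)c1` is not yet measured. It differs from compound 3 by fluoro in place of benzyloxy on an aromatic carbon, the same change as in the measured pair, where it gave a 1.1-fold higher number from compound 2 to compound 1 (0.05 log units; within the scatter). Resting on that step and on compound 3 at 5060 nM, the step to compound 4 is expected to be a 1.1-fold higher number from compound 3 to compound 4 (0.04 log units; within the scatter). Compound 4 is therefore estimated at 5500 nM, between 2500 nM and 12000 nM.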

Compound 4, inhibition constant: 5200 nM
For compound 4 the middle estimate is 1.1-fold (0.02 log units) above the measured one; the measured number falls inside the stated range.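

In this assay fluoro in place of benzyloxy gives a 1.0-fold higher number from compound 3 to compound 4 (0.01 log units; within the scatter) and so carries over to the core of compound 3 with no gap beyond the scatter: the same change on two cores in this assay, a 1.1-fold higher number (0.05 log units; within the scatter) from compound 2 to compound 1 and a 1.0-fold higher number (0.01 log units; within the scatter) from compound 3 to compound 4, 1.1-fold (0.04 log units) apart, within the scatter of two such steps. The larger step of a 7.0-fold higher number from compound 1 to compound 4 (0.84 log units; beyond the scatter) goes with a difference in the drawn configuration alone: the fact that one of compounds 1 and 4 is drawn with a defined configuration and the other without, at the place where they differ. This shows only that fluoro and benzyloxy are not told apart on these two cores in this read-out, and it does not show that the same would hold on any other core.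

Left open is whether an amine, a carboxylic acid or a longer chain on the same aromatic carbon would behave alike on both cores. Also open, on these data alone, is what the opposite configuration at the saturated ring carbon would give.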